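Meta-halogen swap on the triazole N-phenyl of compound 3

The source may hold more compounds than are shown below. What is called first, only, known or untested is meant among the compounds shown, and "the series" means these compounds.

Measured in a functional assay on SGC-7901 cells (Homo sapiens) for antiproliferative activity, read by MTT assay, with a stated time of 24 h; on this read-out lower numbers stand for stronger inhibition and higher numbers for weaker inhibition:
compound 1 `O=c1[nH]cc(S(=O)(=O)Nc2ccccc2-c2cn(-c3ccccc3)nn2)c(=O)[nH]1` gives 11800 nM
compound 2 `O=c1[nH]cc(S(=O)(=O)Nc2ccccc2-c2cn(-c3ccccc3F)nn2)c(=O)[nH]1` gives 10800 nM
compound 3 `O=c1[nH]cc(S(=O)(=O)Nc2ccccc2-c2cn(-c3cccc(F)c3)nn2)c(=O)[nH]1` is reported only as a limit, > 20000 nM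

Compound 3 therefore has no number of its own; its value sits at the limit (the limit of > 20000 nM in this assay, at which 1 of the 3 values shown sits), and the steps of an at least 1.6-fold higher number from compound 1 to compound 3 (0.22 log units; that floor lies within the scatter) and an at least 1.8-fold higher number from compound 2 to compound 3 (0.26 log units; that floor lies within the scatter) both have floors that lie within the scatter, so compound 3 cannot be set apart from compound 1 or compound 2 on these data. Compound 4 `O=c1[nH]cc(S(=O)(=O)Nc2ccccc2-c2cn(-c3cccc(Cl)c3)nn2)c(=O)[nH]1` differs from compound 3 by chloro in place of fluoro on an aromatic carbon. Going by the values given here, no measured step in this set exchanges one halogen for another; the only steps known, a 1.1-fold lower number from compound 1 to compound 2 (0.04 log units; within the scatter) and an at least 1.6-fold higher number from compound 1 to compound 3 (0.22 log units; that floor lies within the scatter), concern fluoro entering for hydrogen and are within the scatter or at a floor within it. Nothing here points to a shift beyond the scatter in this assay , and a step that the limit leaves unreadable from compound 3 to compound 4 is expected, with a fair chance that compound 4 again returns only a limit. Compound 4 is estimated at 22000 nM, between 9000 nM and 50000 nM.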

Compound 4, half-maximal inhibitory concentration: 2270 nM
Compound 4: the middle estimate sits 9.7-fold (0.99 log units) above what was measured; the measured number lies below the stated range.
By their numbers in this assay, from the lowest: compound 4; then compounds 2 and 1 (each within the scatter of the next). At a limit, above all of these: compound 3.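

In this assay, the halogen on this aromatic carbon now makes a difference, whereas the earlier fluoro steps stayed within the scatter or had floors within it: chloro in place of fluoro gives an at least 8.8-fold lower number from compound 3 to compound 4 (0.94 log units; beyond the scatter). Chloro in place of hydrogen gives a 5.2-fold lower number from compound 1 to compound 4 (0.72 log units; beyond the scatter), and 3-chlorophenyl in place of 2-fluorophenyl gives a 4.8-fold lower number from compound 2 to compound 4 (0.68 log units; beyond the scatter), so compound 4 is the one compound set apart from all the others. The size of the step from the fluoro analogue remains a floor, since compound 3 is reported only as a limit: the limit of > 20000 nM in this assay, at which 1 of the 4 values shown sits.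

The compounds shown leave open whether this gain belongs to chloro alone or extends to bromo, methyl or trifluoromethyl on the same carbon. They also leave open whether it holds in other cell lines or at other exposure times.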